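Lengthening the chain and adding a methoxy group

This account rests on a few compounds, and the source may have more. Where it says the series, first, only, none or still open, it means among the compounds named here.

Measured compounds:
compound 1 `COc1ccc(Cc2nc(N)c3nn(-c4ccccc4)cc3n2)cc1` gives 38% in an assay on CHO cells for displacement of a labelled ligand from adenosine receptor A3 (Homo sapiens), read by scintillation counting, tested at 1 uM; a lower number here means less inhibition, a higher number more inhibition at the concentration tested (going by the name of the read-out)
compound 2 `Nc1nc(CCc2ccccc2)nc2cn(-c3ccccc3)nc12` gives 17%

Compound 2 stands lowest of the two numbers, the nearest being compound 1, and the step of a number 21 percentage points lower from compound 1 to compound 2 (beyond the scatter) lay beyond the scatter. Compound 3 `COc1cccc(CCCc2nc(N)c3nn(-c4ccccc4)cc3n2)c1` differs from compound 2 as follows: 3-methoxybenzyl in place of phenyl on a saturated chain carbon, two bonds along the chain from an aromatic carbon. Among the compounds with values here, the one measured step bears on this only in part, since it combined a methoxy group with a chain change, yet it is the sole guide. An upward move of modest size is therefore expected, a number 11 percentage points higher from compound 2 to compound 3 (beyond the scatter), because of a number 21 percentage points lower from compound 1 to compound 2 (beyond the scatter). Compound 3 is estimated at 28%, within 10% to 50%.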

Compound 3, a percentage reported as inhibition, at one concentration (the size of the read-out at that concentration, not a potency): 33%
The estimate for compound 3 lay 5 percentage points below the measured number; the measured number falls inside the stated range.
By their numbers in this assay, from the lowest: compound 2; then compounds 3 and 1 (each within the scatter of the next).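

Replacing phenyl with 3-methoxybenzyl on the saturated chain carbon gave a number 16 percentage points higher from compound 2 to compound 3 (beyond the scatter) in this assay, so a larger group holding one hydrogen-bond acceptor is accepted at this position. Compound 3 and compound 1 lie within the scatter of each other, although their chains differ. Nothing measured here accounts for the rise.

Going by these compounds, whether the methoxy group or the longer chain carries the rise stays open, since this step changes both at once. Also open, on these data alone, is how a hydroxyl or an amine in place of the methoxy group would read.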